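Series notes: bromination of the hydroxyphenyl amide

A few compounds are considered here, and "the series" means these few. Any claim that something is new, unique, unknown or untested is made for them only; others in the source may bear on it.

Measured compounds:
Compound 1 `COc1ccc(Br)cc1C(=O)Nc1ccc(Sc2nc3ccccc3s2)cc1` — in an assay on isolated protein for inhibition of thiosulfate sulfurtransferase (Homo sapiens), with a stated time of 60 min, in the absence of a further agent (on this read-out lower numbers stand for stronger inhibition and higher numbers for weaker inhibition), compound 1 gives > 100000 nM, which is a limit of the assay and not a number.
Compound 2 `O=C(Nc1ccc(Sc2nc3ccccc3s2)c(Cl)c1)c1cccc(Br)c1O` — in this assay compound 2 gives > 100000 nM, again a limit of the assay.
Compound 3 `O=C(Nc1ccc(Sc2nc3ccccc3s2)cc1)c1ccccc1O` — in this assay compound 3 gives > 100000 nM, also a limit of the assay.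

Compound 3 therefore stands only at a limit, and the two other values shown are limits as well, so no order among the three compounds can be read; all sit at the limit of > 100000 nM in this assay, at which 3 of the 3 values shown sit. Within the data shown here, the single step between measured compounds, a step that the two limits leave unreadable from compound 1 to compound 3, is unreadable for the same reason.

Compound 4 `O=C(Nc1ccc(Sc2nc3ccccc3s2)cc1)c1cccc(Br)c1O` differs from compound 3 by bromo in place of hydrogen on an aromatic carbon. Among the measured compounds shown here, no measured step bears on this change with a readable size, so there is no basis to expect movement in either direction beyond the scatter. The nearest indication is the limit of > 100000 nM in this assay, at which 3 of the 3 values shown sit, at which every measured member of the series sits. Compound 4 is consequently expected to remain at or near that limit, the expected step of a number no higher from compound 3 to compound 4 (the limit leaves the size open) being essentially none. The estimate for compound 4 in this assay is 100000 nM, within 30000 nM to 300000 nM, with a high chance that only a limit is reported.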

Compound 4, half-maximal inhibitory concentration: > 100000 nM
Compound 4: only a limit was reported; the forecaster's own chance of this, stated with the estimate: 80%; the middle value lies on the limit itself.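

Among these compounds, compound 4 gives only a limit of the assay, as do compound 1, compound 2 and compound 3, so no step among them can be read: the limit of > 100000 nM in this assay, at which 4 of the 4 values shown sit. The compounds shown leave open whether bromo in place of hydrogen on an aromatic carbon changes inhibition at all, and how these compounds rank.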